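The source may hold more compounds than are shown below. What is called first, only, known or untested is meant among the compounds shown, and "the series" means these compounds.

Working notes on the series around a functional assay on CHO cells with adenosine receptor A1 (Homo sapiens) as the target, read by cAMP accumulation and immunoassay, with a stated time of 6 min, tested at 1 uM; on this read-out lower numbers stand for a stronger effect and higher numbers for a weaker effect at the one concentration tested.

Compound 1 `Nc1scc(CN2CCN(c3cccc(Cl)c3Cl)CC2)c1C(=O)c1ccc(Cl)cc1` gives -57% in this assay. Compound 2 `Nc1scc(CN2CCN(c3cccc4ccccc34)CC2)c1C(=O)c1ccc(Cl)cc1` gives 2.9% and compound 3 `Nc1scc(CN2CCN(c3cccc(F)c3F)CC2)c1C(=O)c1ccc(Cl)cc1` gives -66%. On these three numbers compound 1 stands second highest: its nearest neighbour is compound 3, lower by an amount within the scatter, and its furthest is compound 2, higher by an amount beyond the scatter.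

The step to compound 4 `Nc1scc(CN2CCN(c3cc(F)ccc3F)CC2)c1C(=O)c1ccc(Cl)cc1` is 2,5-difluorophenyl in place of 2,3-dichlorophenyl on an amine nitrogen in a ring. For the measured compounds named here, two measured steps bear on it. The step of a number 9 percentage points lower from compound 1 to compound 3 (within the scatter) swaps the two chlorines for two fluorines at the same two positions on the aryl group and stays within the scatter. The step of a number 59.9 percentage points higher from compound 1 to compound 2 (beyond the scatter) replaces the substituted phenyl with naphthalen-1-yl and is large, but that change is of a different kind from a change of halogen. Going by the values given here, no measured pair shows 2,5-difluorophenyl against 2,3-difluorophenyl, so the effect of moving one fluorine is not covered.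

On that basis the expected step is a number 2 percentage points higher from compound 1 to compound 4 (within the scatter), that is, no change beyond the scatter. Compound 4 is therefore estimated at -55%, with a range from -80% to -20%.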

Compound 4, a percentage reported as activity, at one concentration (the size of the read-out at that concentration, not a potency): -59%
Estimate against measurement, compound 4: 4 percentage points above; the measured number falls inside the stated range.
By their numbers in this assay, from the lowest: compounds 3, 4 and 1 (each within the scatter of the next); then compound 2.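

In this assay, 2,5-difluorophenyl on the amine nitrogen in the ring cannot be told apart from 2,3-dichlorophenyl (a number 2 percentage points lower from compound 1 to compound 4 (within the scatter)) or from 2,3-difluorophenyl (a number 7 percentage points higher from compound 3 to compound 4 (within the scatter)), so the second of these pairs now covers a different placing of the two fluorines on the aryl group, and at this read-out that placing makes no difference beyond the scatter. The gap to naphthalen-1-yl remains large (a number 61.9 percentage points lower from compound 2 to compound 4 (beyond the scatter)), which leaves compound 2 as the only one of the four set apart, while compounds 1, 3 and 4 form a single level across two halogens and two substitution patterns. Nothing measured here offers an explanation for either the shared level or the gap.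

The compounds shown leave open whether this level depends on halogens at all, since a phenyl group carrying methoxy or trifluoromethyl, or an unsubstituted phenyl, would test that directly. They also leave open whether the same insensitivity holds when the 4-chlorophenyl group on the carbonyl of the shared core gives way to a plain phenyl or a pyridine.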